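The source may hold more compounds than are shown below. What is called first, only, known or untested is meant among the compounds shown, and "the series" means these compounds.

Of the compounds shown here, three sharing one core have been measured in a functional assay on L1210 cells (Mus musculus) for inhibition, read by MTT assay, with a stated time of 72 h (on this read-out lower numbers stand for stronger inhibition and higher numbers for weaker inhibition), and they differ only in the group on an amide-type nitrogen. Compound 1 `COc1cc(NC(C)CCCNC(=O)NNC(=O)Nc2ccc(F)cc2)c2ncccc2c1` gives 104000 nM while compound 2 `COc1cc(NC(C)CCCNC(=O)NNC(=O)Nc2ccc(C(F)(F)F)cc2)c2ncccc2c1` gives 18000 nM and compound 3 `COc1cc(NC(C)CCCNC(=O)NNC(=O)Nc2ccc(Br)cc2)c2ncccc2c1` gives 51000 nM on this read-out. Compound 3 therefore holds the middle place of the three numbers, with a 2.0-fold lower number from compound 1 to compound 3 (0.31 log units; beyond the scatter) on one side and a 2.8-fold higher number from compound 2 to compound 3 (0.45 log units; beyond the scatter) on the other. For the measured compounds named here, the next compound, compound 4 `COc1cc(NC(C)CCCNC(=O)NNC(=O)Nc2cccc(C(F)(F)F)c2)c2ncccc2c1`, carries 3-(trifluoromethyl)phenyl in place of 4-bromophenyl on an amide-type nitrogen and no measured compound has this exact group. The nearest guides are the modest 2.8-fold higher number from compound 2 to compound 3 (0.45 log units; beyond the scatter) for bromo in place of trifluoromethyl, read backwards, and the modest 5.8-fold lower number from compound 1 to compound 2 (0.76 log units; beyond the scatter) for trifluoromethyl in place of fluoro. Both favour trifluoromethyl, so a modest move to a lower number is expected, namely an estimated 2.1-fold lower number from compound 3 to compound 4 (0.33 log units; beyond the scatter) in this assay once measured. Compound 4 is estimated at 24000 nM with an expected range of 10000 nM to 55000 nM for its measurement.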

Compound 4, half-maximal inhibitory concentration: 4000 nM
Estimate against measurement, compound 4: 6.0-fold (0.78 log units) above; measured number below the stated range.
By their numbers in this assay, from the lowest: compound 4; then compound 2; then compound 3; then compound 1.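

In this assay, going from the 4-(trifluoromethyl)phenyl group to the 3-(trifluoromethyl)phenyl group gives a 4.5-fold lower number from compound 2 to compound 4 (0.65 log units; beyond the scatter), so on this amide-type nitrogen the read-out depends on where the trifluoromethyl sits on the phenyl ring and not only on which group the ring carries. The change also gives a 13-fold lower number from compound 3 to compound 4 (1.11 log units; beyond the scatter) and a 26-fold lower number from compound 1 to compound 4 (1.41 log units; beyond the scatter), both large, whereas every step among the three earlier compounds was modest. Nothing available here accounts for this difference between the two trifluoromethyl isomers.

Among the compounds shown, trifluoromethyl is the only group on a 3-substituted phenyl, so it stays open whether the gain belongs to that group or to the placement itself. A 3-bromophenyl, 3-fluorophenyl or 3-methoxyphenyl group, or plain phenyl, would help to separate the two.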